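The source may hold more compounds than are shown below. What is called first, only, known or untested is meant among the compounds shown, and "the series" means these compounds.

Working notes on the cytotoxicity series.

Compound 1 `O=C(CN1CCN(c2cccc(Cl)c2)CC1)N1CCN(c2nnc(-c3ccccc3)c(-c3ccccc3)n2)CC1` is the reference. In an ADME assay on NIH3T3 cells (Mus musculus) for cytotoxicity, read by MTT assay, with a stated time of 24 h (a higher number here means a weaker inhibitor, a lower number a stronger inhibitor), compound 1 gives 178000 nM. Compound 2 `COc1ccc(N2CCN(CC(=O)N3CCN(c4nnc(-c5ccccc5)c(-c5ccccc5)n4)CC3)CC2)cc1` carries 4-methoxyphenyl in place of 3-chlorophenyl on an amine nitrogen in a ring. For compound 2 this assay reports only a limit, > 910000 nM. The step of an at least 5.1-fold higher number from compound 1 to compound 2 (0.70 log units; beyond the scatter) is therefore bounded from below only, since compound 2 sits at the limit (the limit of > 910000 nM in this assay, at which 1 of the 3 values shown sits).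

Compound 3 `COc1ccc(-c2nnc(N3CCN(C(=O)CN4CCN(c5cccc(Cl)c5)CC4)CC3)nc2-c2ccc(OC)cc2)cc1` shares the 3-chlorophenyl side with compound 1; how its core differs from the core of compound 1 is not broken down here. For compound 3 this assay gives only a limit, > 814000 nM. That is the limit (the limit of > 814000 nM in this assay, at which 1 of the 3 values shown sits).

Compound 4 `COc1ccc(-c2nnc(N3CCN(C(=O)CN4CCN(c5ccc(OC)cc5)CC4)CC3)nc2-c2ccc(OC)cc2)cc1`, not yet measured, carries 4-methoxyphenyl in place of 3-chlorophenyl on an amine nitrogen in a ring, the same change as from compound 1 to compound 2. Compound 3 already sits at a limit, so the step from compound 3 to compound 4 cannot be resolved as a number by this assay; compound 4 is expected to remain at or beyond that limit, the expected step being a step that the limit leaves unreadable from compound 3 to compound 4, resting on compound 3 at > 814000 nM and on the direction of the step from compound 1 to compound 2. The expected value for compound 4 in this assay is 1000000 nM, most likely reported as a limit.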

Compound 4, half-maximal inhibitory concentration: > 821000 nM
Compound 4: a limit, no number; the forecaster's own chance of this, stated with the estimate: 85%; the middle value is on the limit's open side.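

In this assay compound 3 gives only a limit, > 814000 nM. Compound 4 also gives only a limit, > 821000 nM. Within the data shown here, with both values at limits, no step from compound 3 to compound 4 can be read. The compounds shown leave open whether 4-methoxyphenyl in place of 3-chlorophenyl moves the value on the core of compound 3 at all, and by how much.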